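Swapping the Aryl Group on the Aromatic Nitrogen

The source may report more compounds than this note shows. Statements on the series, on what has been measured and on what is new or still open speak of the compounds shown alone.

Of the compounds shown here, two have numbers so far. Compound 1 `N#CC1=C(N)Oc2c(c3nc4ccccc4nc3c3ccccc23)C12C(=O)N(Cc1cnnn1-c1cccc(Cl)c1)c1ccccc12` gives 32600 nM in a functional assay on A549 cells (Homo sapiens) for antiproliferative activity, read by MTT assay, with a stated time of 48 h; a lower number here means a stronger inhibitor, a higher number a weaker inhibitor. Compound 2 `N#CC1=C(N)Oc2c(N)cc3nc4ccccc4nc3c2C12C(=O)N(Cc1cnnn1-c1ccccc1Br)c1ccccc12` gives 27400 nM in this assay. Compound 2 holds the lower of the two numbers, but the gap to compound 1 lies within the usual scatter of repeated measurements, so the two values cannot be told apart and neither compound can be called the stronger inhibitor.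

Compound 3 `Cc1cc(C)c(-n2nncc2CN2C(=O)C3(C(C#N)=C(N)Oc4c(N)cc5nc6ccccc6nc5c43)c3ccccc32)c(C)c1` has not yet been measured. It differs from compound 2 in a single place: 2,4,6-trimethylphenyl in place of 2-bromophenyl on an aromatic nitrogen. The 2-bromophenyl leaves and a 2,4,6-trimethylphenyl enters, both plain carbon rings with no hydrogen-bond donors or acceptors and no charge. Going by the values given here, no pair of measured compounds isolates a change of this kind, so the data give no direction for it, and the two numbers at hand agree with each other.

The expected step is therefore a 1.1-fold higher number from compound 2 to compound 3 (0.04 log units; within the scatter), that is, no change beyond the scatter. Compound 3 is estimated at 30000 nM, with a range from 10000 nM to 90000 nM.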

Compound 3, half-maximal inhibitory concentration: 12700 nM
For compound 3 the middle estimate is 2.4-fold (0.37 log units) above the measured one; the range from low to high includes it.
By their numbers in this assay, from the lowest: compound 3; then compounds 2 and 1 (each within the scatter of the next).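

This position, on an aromatic nitrogen of a five-membered aromatic ring with 3 nitrogen, is not indifferent to the aryl group it carries: in this assay, putting 2,4,6-trimethylphenyl in place of 2-bromophenyl gives a 2.2-fold lower number from compound 2 to compound 3 (0.33 log units; beyond the scatter) and so separates two compounds in this series by more than the scatter. The step is modest, but it shows that a carbon-only substituted aryl group without bromine can give a stronger inhibitor here than the 2-bromophenyl group does. Nothing at hand accounts for this gain, so its cause remains unknown.

The bromine leaves and the methyl groups enter in a single change, so these compounds cannot show which of the two matters, and a plain phenyl group would help to separate them. As far as these compounds go, it also remains open how this position would respond to a methoxy group, an amine or a carboxylic acid on the aryl ring, and whether the same change would give a similar step on the core of compound 1.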